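The source may report more compounds than this note shows. Statements on the series, on what has been measured and on what is new or still open speak of the compounds shown alone.

Three compounds were measured in an in vitro assay on LLC-PK1 cells for displacement of a labelled ligand from growth hormone secretagogue receptor type 1 (Homo sapiens); a higher number here means a weaker inhibitor, a lower number a stronger inhibitor. Compound 1 `COc1ccc(Cn2c(CCc3ccccc3)nnc2[C@H](NC(=O)C(C)(C)N)c2c[nH]c3ccccc23)cc1` gives 11 nM, compound 2 `COc1ccc(Cn2c(CCc3ccccc3)nnc2[C@H](NC(=O)c2ccncc2)c2c[nH]c3ccccc23)cc1` gives 220 nM, and compound 3 `CCc1ccc(Cn2c(CCc3ccccc3)nnc2[C@H](NC(=O)Cc2ccccn2)c2c[nH]c3ccccc23)cc1` gives 51 nM. Compound 3 thus stands second highest of the three, with compound 2 nearest and compound 1 furthest. Within the data shown here, the one single-site step recorded, a 20-fold higher number from compound 1 to compound 2 (1.30 log units; beyond the scatter), concerns the amide and does not touch the benzyl substituent. Compound 4 `COc1ccc(Cn2c(CCc3ccccc3)nnc2[C@H](NC(=O)Cc2ccccn2)c2c[nH]c3ccccc23)cc1` arises from compound 3 by methoxy in place of ethyl on an aromatic carbon. Among the measured compounds shown here, no measured step bears directly on this change, so the expectation rests on the absence of evidence for a large effect and is a step of a 1.1-fold lower number from compound 3 to compound 4 (0.05 log units; within the scatter), within the scatter. Compound 4 is therefore expected at about 45 nM, with a range from 15 nM to 130 nM.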

Compound 4, half-maximal inhibitory concentration: 3 nM
For compound 4 the middle estimate is 15-fold (1.18 log units) above the measured one, and the stated range ends above it.
By their numbers in this assay, from the lowest: compound 4; then compound 1; then compound 3; then compound 2.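

In this assay the substituent on the benzyl ring proves far from neutral: a 17-fold lower number from compound 3 to compound 4 (1.23 log units; beyond the scatter) with methoxy in place of ethyl on an aromatic carbon para to a large group. With methoxy in that place, (pyridin-2-yl)methyl on the carbonyl carbon outdoes pyridin-4-yl in a 73-fold lower number from compound 2 to compound 4 (1.87 log units; beyond the scatter) and, by less, 1-amino-1-methylethyl in a 3.7-fold lower number from compound 1 to compound 4 (0.56 log units; beyond the scatter) and the step is still beyond the scatter. Nothing available explains why the methoxy group gives this gain. Still open, going by these compounds, is whether ethoxy, a hydroxyl or a chlorine atom in this place would match methoxy.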